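Removing the 2-Fluorobenzyl Ester: Expectation for Compound 3

The compounds below may be only part of what the source reports. "The series", "measured", "known", "first", "only" and "open" are said of these compounds alone.

Measured so far:
- compound 1, `CCOC(=O)c1cscc1-c1ccc(OC)c(OC)c1`: 3%
- compound 2, `COc1ccc(-c2csc(N)c2C(=O)OCc2ccccc2F)cc1OC`: 100%

In an assay on isolated protein for inhibition of protein kinase C zeta type (Homo sapiens), with stated times of 1 h and 2.5 min, tested at 30 uM (a lower number here means less inhibition, a higher number more inhibition at the concentration tested (going by the name of the read-out)), compound 2 gives the higher of the two numbers, and compound 1 gives a number far lower, a gap well beyond the usual scatter. Compound 3, `COc1ccc(-c2csc(N)c2C(=O)O)cc1OC`, has not been measured. It differs from compound 2 in one place: hydrogen in place of 2-fluorobenzyl on an oxygen next to a carbonyl group. Among the compounds with values here, no measured pair shows this change, so its size is unknown. A loss of inhibition is expected, of uncertain size, and the expected step of a number 55 percentage points lower from compound 2 to compound 3 (beyond the scatter) reflects that. Compound 3 is therefore estimated at 45%, within a range from 5% to 90%.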

Compound 3, a percentage reported as inhibition, at one concentration (the size of the read-out at that concentration, not a potency): 65%
For compound 3 the middle estimate is 20 percentage points below the measured one, within the range that was stated.
By their numbers in this assay, from the lowest: compound 1; then compound 3; then compound 2.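

In this assay, replacing 2-fluorobenzyl with hydrogen on this oxygen gives a number 35 percentage points lower from compound 2 to compound 3 (beyond the scatter), so at this position the change costs inhibition at the concentration tested. Even so, the 2-fluorobenzyl group is not required for inhibition: compound 3, with a hydroxy in place of (2-fluorobenzyl)oxy, still gives 65%. No measurement shown here explains the size of this step.

Whether the fluorine contributes remains open, since a plain benzyl ester is not among these compounds. From the compounds shown here alone, how a methyl ester or an amide would behave at this position is also open.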